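Dimethoxyphenyl swap on the saturated ring carbon

A few compounds are considered here, and "the series" means these few. Any claim that something is new, unique, unknown or untested is made for them only; others in the source may bear on it.

Going by the values given here, compound 1 `COc1ccc(C2OC(c3cc(OC)c(OC)c(OC)c3)=NN2C(C)=O)c(OC)c1` stands at the lower of the two numbers so far in a functional assay on BGC-823 cells (Homo sapiens) for antiproliferative activity, read by MTT assay, tested at 5 uM (a higher number here means a stronger effect of the compound at the concentration tested, a lower number a weaker effect), where compound 1 gives -3.1%. Compound 2 `COc1cccc(/C=N/NC(=O)c2cc(OC)c(OC)c(OC)c2)c1OC` is built on a different framework and is not a single-change neighbour of compound 1; in this assay compound 2 gives 14.2%, a reading higher than that of compound 1 by more than the usual scatter, though both remain weak at the concentration tested.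

Compound 3 `COc1cc(C2=NN(C(C)=O)C(c3cccc(OC)c3OC)O2)cc(OC)c1OC` is the untested partner of compound 1. The change is 2,3-dimethoxyphenyl in place of 2,4-dimethoxyphenyl on a saturated ring carbon, with the shared core and its acetyl group left untouched. Among the compounds with values here, no measured pair shows what this exchange does here, so the expectation rests on the near-zero value of compound 1 and on the small spread of the whole set. The expected step from compound 1 to compound 3 in this assay is small and without a clear direction, a number 7.1 percentage points higher from compound 1 to compound 3 (within the scatter), most likely within the scatter. Compound 3 is therefore expected to give about 4% in this assay, within a range of -10% to 20%.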

Compound 3, a percentage reported as inhibition, at one concentration (the size of the read-out at that concentration, not a potency): 17.5%
Estimate against measurement, compound 3: 13.5 percentage points below, and the stated range covers the measured number.
By their numbers in this assay, from the lowest: compound 1; then compounds 2 and 3 (each within the scatter of the next).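

On the saturated ring carbon, the arrangement of the methoxy groups on the phenyl ring is not neutral in this assay: 2,3-dimethoxyphenyl in place of 2,4-dimethoxyphenyl gives a number 20.6 percentage points higher from compound 1 to compound 3 (beyond the scatter) while the shared core, its acetyl group and the atom count stay the same. Going by these compounds alone, this is the first single-change pair, and it shows that an exchange between two isomeric groups at this position can move the reading by more than the scatter. The step rests on one pair at a single concentration, so it describes the size of the effect at that concentration and not a potency, and nothing available here accounts for it.

From the compounds shown here alone, it remains open whether the step carries over to other groups at this position, such as a hydroxyl, an amine or a 3,4-dimethoxyphenyl ring in place of the 2,3-dimethoxyphenyl group. Going by these compounds, it is equally open whether the same exchange gives a comparable step when a propionyl group stands in place of the acetyl group on the shared core.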